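The source may report more compounds than this note shows. Statements on the series, on what has been measured and on what is new or still open speak of the compounds shown alone.

Measured so far:

Compound 1, `CN1CCC[C@@H]1Cn1nc(Cc2cccc(Cl)c2)c2ccccc2c1=O`, gives 398 nM in an assay for binding affinity to Alpha-1A adrenergic receptor (Homo sapiens); a higher number here means a weaker inhibitor, a lower number a stronger inhibitor.
Compound 2, `CN1CCC[C@@H]1Cn1nc(Cc2ccc(C(C)(C)C)cc2)c2ccccc2c1=O`, gives only > 1990 nM in this assay, which is a limit of the assay and not a number.

Compound 1 therefore stands at the only actual number shown in this assay; the other entry is a limit, (the limit of > 1990 nM in this assay, at which 1 of the 2 values shown sits). Compound 3, `CN1CCC[C@@H]1Cn1nc(Cc2cccc(F)c2)c2ccccc2c1=O`, has not been measured. It differs from compound 1 in one place: fluoro in place of chloro on an aromatic carbon. For the measured compounds named here, no measured pair in this set shows what such a swap does, so the size of the step has to be guessed. A change of this kind is expected to stay close to the scatter of repeated measurements, if anything leaning toward weaker binding, so the step from compound 1 to compound 3 is estimated as a 1.5-fold higher number from compound 1 to compound 3 (0.18 log units; within the scatter). Compound 3 is therefore expected to give about 600 nM, somewhere between 250 nM and 1500 nM.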

Compound 3, inhibition constant: 50.1 nM
For compound 3 the middle estimate is 12-fold (1.08 log units) above the measured one, outside the stated range (below it).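

In this assay, going from 3-chlorobenzyl to 3-fluorobenzyl gives a 7.9-fold lower number from compound 1 to compound 3 (0.90 log units; beyond the scatter), so swapping a single atom at this place on the ring can change binding clearly. For the compounds shown here, compound 1 and compound 2 differ in more than one place, which makes this the first pair here that tests one change on its own. Nothing shown here explains why this swap has so large an effect.

This reading rests on a single pair of halogens at one place, so it cannot yet be called a trend. Plain hydrogen, a methoxy group or a trifluoromethyl group at the same place would show whether the chloro group costs binding, the fluoro group adds to it, or both are true.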